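Replacing a two-ring group with 2-fluorophenyl

The compounds below may be only part of what the source reports. "The series", "measured", "known", "first", "only" and "open" are said of these compounds alone.

Compound 1 `COc1ccc(F)cc1N1C(=O)CSC1c1cccc(C(=O)NCCCCn2cccn2)c1` gives 50000 nM
Compound 2 `Cc1cccc(N2C(=O)CSC2c2cccc(C(=O)NCCCCc3ccccc3)c2)c1` gives 10000 nM
Compound 3 `O=C(NCCCCc1ccccc1)c1cccc(C2SCC(=O)N2c2cccc(-c3c[nH]nn3)c2)c1` gives 20000 nM

All three numbers come from a physicochemical assay for solubility, read by turbidimetry, measured as kinetic solubility, at pH 6.8; on this read-out higher numbers stand for higher solubility and lower numbers for lower solubility. Repeat measurements of this kind naturally scatter, so small gaps carry little meaning. Compound 3, at 20000 nM, cannot be told apart from compound 2, at 10000 nM. Compound 1, at 50000 nM, stands higher than compound 3 by more than the scatter.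

The next molecule is compound 4 `O=C(NCCCCc1ccccc1)c1cccc(C2SCC(=O)N2c2ccccc2F)c1`, which differs from compound 3 in one place: a group of 7 heavy atoms (6 carbon, 1 fluorine; one six-membered aromatic ring of carbon only) in place of a group of 11 heavy atoms (8 carbon, 3 nitrogen; one five-membered aromatic ring with 3 hetero atoms, one six-membered aromatic ring of carbon only), on an amide-type nitrogen in a ring. The group that leaves has no common name, and the group that enters is 2-fluorophenyl.

Among the measured compounds shown here, only one measured step offers a guide, a 2.0-fold higher number from compound 2 to compound 3 (0.30 log units; within the scatter), and it stayed within the scatter. For the measured compounds named here, no measured step connects compound 1 to the others, so it offers no step size to borrow. Going by the values given here, no measured compound here carries 2-fluorophenyl, so the range has to stay wide. On this thin evidence, no change beyond the scatter is expected in this assay. The estimated change is a 1.3-fold lower number from compound 3 to compound 4 (0.12 log units; within the scatter). For compound 4 the expected value is 15000 nM, with an estimated range from 6000 nM to 35000 nM.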

Compound 4, solubility: 20000 nM
Compound 4: the middle estimate sits 1.3-fold (0.12 log units) below what was measured; measured number inside the range.
By their numbers in this assay, from the lowest: compounds 2, 3 and 4 (each within the scatter of the next); then compound 1.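

In this assay, putting 2-fluorophenyl on the amide-type nitrogen in place of the larger group, with its five-membered aromatic ring holding 3 hetero atoms, gives (no change at the digits printed from compound 3 to compound 4 (within the scatter)), even though the swap removes 1 hydrogen-bond donor and 2 hydrogen-bond acceptors. Replacing 3-methylphenyl at the same place gives (a 2.0-fold higher number from compound 2 to compound 4 (0.30 log units; within the scatter)), so the read-out does not separate these three groups on this nitrogen, a wider comparison than the earlier single step on an aromatic carbon could offer. No other information is available here to explain this outcome.

Compound 1, at 50000 nM, differs from compounds 2, 3 and 4 in more than one place, so its number cannot be traced to any single group. On these data alone, it remains open whether a phenyl ring on this nitrogen carrying an amine or a carboxylic acid would move the number beyond the scatter, and whether the end of the chain on the other amide matters more than this position.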